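A few compounds are considered here, and "the series" means these few. Any claim that something is new, unique, unknown or untested is made for them only; others in the source may bear on it.

Measured so far:
- compound 1 `CCn1c(C(=O)N[C@@H](CO)CCCO)ccc1C(CC)(CC)c1ccc(OCS(=O)(=O)c2ccccc2)c(C)c1`: 29600 nM
- compound 2 `CCn1c(C(=O)N[C@H](C)C(=O)O)ccc1C(CC)(CC)c1ccc(OCS(=O)(=O)c2ccccc2)c(C)c1`: > 50000 nM (a limit)

In a functional assay on MCF7 cells (Homo sapiens) for antiproliferative activity, read by MTT assay, with a stated time of 24 h (on this read-out higher numbers stand for weaker inhibition and lower numbers for stronger inhibition), compound 2 stands at > 50000 nM, which is a limit of the assay and not a number. Compound 3 `CCn1c(C(=O)N[C@@H](C(=O)O)C(C)C)ccc1C(CC)(CC)c1ccc(OCS(=O)(=O)c2ccccc2)c(C)c1` differs from it as follows: isopropyl in place of methyl on a saturated chain carbon bound to an amide-type nitrogen and a carbonyl carbon. For the measured compounds named here, only one measured step bears on this change, and only loosely, as it also alters the group on the amide-type nitrogen: an at least 1.6-fold higher number from compound 1 to compound 2 (0.22 log units; that floor lies within the scatter). That step gives no size for the present change, so no step beyond the scatter is expected in this assay. The expected step is a number no higher from compound 2 to compound 3 (the limit leaves the size open). Compound 3 is estimated at 50000 nM, with an expected range of 28000 nM to 90000 nM.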

Compound 3, half-maximal inhibitory concentration: 44700 nM
Beside the measured number, compound 3's estimate is 1.1-fold (0.05 log units) above it; low and high end bracket the measured number.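

In this assay, isopropyl in place of methyl on a saturated chain carbon bound to an amide-type nitrogen and a carbonyl carbon gives an at least 1.1-fold lower number from compound 2 to compound 3 (0.04 log units; that floor lies within the scatter). Exchanging the whole group on the amide-type nitrogen gives a 1.5-fold higher number from compound 1 to compound 3 (0.18 log units; within the scatter), so the 1-carboxy-2-methylpropyl group reads no differently from the group of compound 1. Compound 2 stands at a limit of the assay, not a number: the limit of > 50000 nM in this assay, at which 1 of the 3 values shown sits.

From the compounds shown here alone, whether a longer chain or an amine on that saturated chain carbon would move the number beyond the scatter stays open. Going by these compounds, how an ester in place of the carboxylic acid would read also stays open.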